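A Carbamoyl Group in Place of a Carbonyl Aryl

The source may hold more compounds than are shown below. What is called first, only, known or untested is meant among the compounds shown, and "the series" means these compounds.

Of the compounds shown here, three of one series have been measured in a functional assay on Hs-578T cells (Homo sapiens) for inhibition, read by sulforhodamine B assay, with a stated time of 48 h; a higher number here means a weaker inhibitor of growth, a lower number a stronger inhibitor of growth. Compound 1 `COc1cc(-c2nn(-c3cccc(NC(=O)c4cccc(C(F)(F)F)c4)c3)cc2-c2ccncc2)ccc1Cl` gives 1070 nM. Compound 2 `O=C(Nc1cccc(-n2cc(-c3ccncc3)c(-c3ccc(Cl)c(O)c3)n2)c1)Nc1cc(C(F)(F)F)cc(C(F)(F)F)c1` gives 1140 nM, and compound 3 `O=C(Nc1cccc(-n2cc(-c3ccncc3)c(-c3ccc(Cl)c(O)c3)n2)c1)Nc1ccc(Cl)c(C(F)(F)F)c1` gives 797 nM. Compound 1 sits second highest of these three numbers, yet its distances to compound 2 and to compound 3 both fall within the usual scatter, so the three read as equally active. Compound 4 `COc1cc(-c2nn(-c3cccc(NC(=O)Nc4ccc(Cl)c(Cl)c4)c3)cc2-c2ccncc2)ccc1Cl` has not yet been measured. It differs from compound 1 in one place: (3,4-dichlorophenyl)amino in place of 3-(trifluoromethyl)phenyl on a carbonyl carbon. Among the measured compounds shown here, nothing among the measured compounds points to a large move, so the step of a 1.3-fold lower number from compound 1 to compound 4 (0.10 log units; within the scatter) is expected to be small, within the scatter. Compound 4 is expected to give 850 nM, with a range from 350 nM to 2000 nM.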

Compound 4, concentration for 50% growth inhibition: 1430 nM
Estimate against measurement, compound 4: 1.7-fold (0.23 log units) below; low and high end bracket the measured number.
By their numbers in this assay, from the lowest: compounds 3, 1, 2 and 4 (each within the scatter of the next).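

Placing (3,4-dichlorophenyl)amino on the carbonyl carbon instead of 3-(trifluoromethyl)phenyl gives a 1.3-fold higher number from compound 1 to compound 4 (0.13 log units; within the scatter) in this assay. Among the compounds shown here, this is the first one-place comparison, and it shows that this position tolerates the exchange, including the added hydrogen-bond donor, with no clear shift in growth inhibition. No measurement at hand explains why the number holds.

As far as these compounds go, whether an amine or a carboxylic acid on the carbonyl carbon would move the number beyond the scatter stays open. So does the effect of a longer chain there.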